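A few compounds are considered here, and "the series" means these few. Any claim that something is new, unique, unknown or untested is made for them only; others in the source may bear on it.

In a functional assay on DU-145 cells (Homo sapiens) for cytotoxicity, read by sulforhodamine B assay, with a stated time of 48 h (a lower number here means a stronger inhibitor of growth, a higher number a weaker inhibitor of growth), compound 3 (`COc1ccc(C(=O)c2cc(OC)c(OC)c(OC)c2)c(OC)c1N`) gives 27.4 nM. This lies within the scatter of compound 2 (`COc1ccc(C(=O)c2cc(OC)c(OC)c(OC)c2)c(OC)c1O`) at 20.9 nM, whereas compound 1 (`COc1cc(C(=O)c2ccc3c(c2)oc(=O)n3S(C)(=O)=O)cc(OC)c1OC`) gives 3040 nM, a far higher number. Compound 4 (`COc1ccc(C(=O)c2cc(OC)c(OC)c(OC)c2)c(OC)c1NC(C)=O`) follows from compound 3 by acetyl in place of hydrogen on a nitrogen on an aromatic ring, amino to acetamido. For the measured compounds named here, the only measured step at this place, a 1.3-fold higher number from compound 2 to compound 3 (0.12 log units; within the scatter), stays within the scatter, but it involves no acetyl group and gives only weak guidance. Some loss of growth inhibition is still expected, with wide uncertainty. The expected change is a 4.7-fold higher number from compound 3 to compound 4 (0.68 log units; beyond the scatter). The estimated value for compound 4 is 130 nM, within an expected range of 30 nM to 700 nM.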

Compound 4, concentration for 50% growth inhibition: 292 nM
Estimate against measurement, compound 4: 2.2-fold (0.35 log units) below, within the range that was stated.
By their numbers in this assay, from the lowest: compounds 2 and 3 (each within the scatter of the next); then compound 4; then compound 1.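

In this assay the nitrogen at this position does not accept acetyl as it stands: amino to acetamido is a large loss of growth inhibition (an 11-fold higher number from compound 3 to compound 4 (1.03 log units; beyond the scatter)), and acetamido in place of hydroxy is similar in size (a 14-fold higher number from compound 2 to compound 4 (1.15 log units; beyond the scatter)). The within-scatter pair of hydroxy and amino therefore does not extend to every group here. Nothing available explains this loss.

Still open, going by these compounds, is whether a methyl group on the nitrogen stays within the scatter of compound 3 or shows a loss like that of compound 4. A longer acyl chain on the same nitrogen is equally unresolved.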